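Adding a Second Methoxy Group on the Amide-Side Ring

The source may report more compounds than this note shows. Statements on the series, on what has been measured and on what is new or still open speak of the compounds shown alone.

Three compounds sharing one core carry different groups on an amide-type nitrogen. Compound 1 `O=C(Nc1ccc[n+]([O-])c1)c1cc2cnc(Nc3ccc(N4CCNCC4)cn3)nc2n1C1CCCC1` gives 125000 nM in a functional assay on MIA PaCa-2 cells (Homo sapiens) for inhibition, read by MTT assay; on this read-out lower numbers stand for stronger inhibition and higher numbers for weaker inhibition. Compound 2 `COc1cccc(NC(=O)c2cc3cnc(Nc4ccc(N5CCNCC5)cn4)nc3n2C2CCCC2)c1` gives 2650 nM in this assay, and compound 3 `COc1ccc(NC(=O)c2cc3cnc(Nc4ccc(N5CCNCC5)cn4)nc3n2C2CCCC2)cc1` gives 2880 nM. Compound 3 stands second highest of the three numbers: its nearest neighbour is reached by a 1.1-fold higher number from compound 2 to compound 3 (0.04 log units; within the scatter), a gap within the scatter, while a 43-fold lower number from compound 1 to compound 3 (1.64 log units; beyond the scatter) lies far beyond it. Compound 4 `COc1ccc(NC(=O)c2cc3cnc(Nc4ccc(N5CCNCC5)cn4)nc3n2C2CCCC2)c(OC)c1` has not yet been measured; it differs from compound 3 in one place: methoxy in place of hydrogen on an aromatic carbon. The step that bears most on this change is a 1.1-fold higher number from compound 2 to compound 3 (0.04 log units; within the scatter), which shows that moving a methoxy group to another aromatic carbon left the number in this assay essentially unchanged. a 47-fold lower number from compound 1 to compound 2 (1.67 log units; beyond the scatter) and a 43-fold lower number from compound 1 to compound 3 (1.64 log units; beyond the scatter) concern a different exchange and say little here. A second methoxy group is therefore expected to bring no step beyond the scatter, a 1.1-fold lower number from compound 3 to compound 4 (0.03 log units; within the scatter). Compound 4 is estimated at 2700 nM, between 1000 nM and 7000 nM.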

Compound 4, half-maximal inhibitory concentration: 2230 nM
Beside the measured number, compound 4's estimate is 1.2-fold (0.08 log units) above it, and the stated range covers the measured number.
By their numbers in this assay, from the lowest: compounds 4, 2 and 3 (each within the scatter of the next); then compound 1.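

In this assay, methoxy in place of hydrogen on a ring that already carries a methoxy group, at the carbon ortho to a large group, gives a step within the scatter (a 1.3-fold lower number from compound 3 to compound 4 (0.11 log units; within the scatter)), so a second methoxy group leaves the number essentially where it was. The 2,4-dimethoxyphenyl group also stays within the scatter of the 3-methoxyphenyl group (a 1.2-fold lower number from compound 2 to compound 4 (0.07 log units; within the scatter)), while the large gap to the group on compound 1 persists (a 56-fold lower number from compound 1 to compound 4 (1.75 log units; beyond the scatter)), so compounds 2, 3 and 4 form one cluster, well apart from compound 1. No measured information accompanies these numbers to account for this.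

The compounds shown leave open whether an amine or a carboxylic acid at this same ring carbon would sit equally close to compound 3. They also leave open whether a longer chain, such as ethoxy, would do the same.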